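The source may report more compounds than this note shows. Statements on the series, on what has been measured and on what is new or still open speak of the compounds shown alone.

Two compounds share a core built from three joined rings and have been tested in a functional assay on PC-3 cells (Homo sapiens) for inhibition, read by MTT assay, with a stated time of 48 h; a higher number here means a weaker inhibitor, a lower number a stronger inhibitor. Compound 1 `COc1ccc(-n2c(SCc3ccc(C)cc3)nnc2-c2cc(OC)c(OC)c(OC)c2)cc1` gives 56500 nM. Compound 2 `COc1ccc(-n2c(SCc3ccc(F)cc3)nnc2-c2cc(OC)c(OC)c(OC)c2)cc1` gives 35000 nM. Among the measured compounds shown here, the single step among them, a 1.6-fold lower number from compound 1 to compound 2 (0.21 log units; within the scatter), falls within the scatter, so the two numbers cannot be told apart. Compound 2 carries the lower of the two numbers, but its distance to compound 1 is within the scatter.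

Compound 3 `CCOC(=O)CSc1nnc(-c2cc(OC)c(OC)c(OC)c2)n1-c1ccc(OC)cc1` has not been measured. It differs from compound 2 by a single change: ethoxycarbonyl in place of 4-fluorophenyl on a saturated chain carbon bound to a sulfur. For the measured compounds named here, no measured step concerns this kind of change; the only step known swaps one group on an aromatic ring for another and stayed within the scatter. Any direction is therefore open, and a step beyond the scatter in this assay cannot be excluded in either direction.

Compound 3 is expected to give about 40000 nM, estimated within 10000 nM to 160000 nM, which means an expected step of a 1.1-fold higher number from compound 2 to compound 3 (0.06 log units; within the scatter).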

Compound 3, half-maximal inhibitory concentration: > 60000 nM
Compound 3: a limit, no number; the forecaster's own chance of this, stated with the estimate: 20%; middle value at least 1.5-fold (0.17 log units) from the limit.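

Compound 3 gives no number, only a limit of the assay: the limit of > 60000 nM in this assay, at which 1 of the 3 values shown sits.

Where the earlier step only swapped a group on an aromatic ring, this change removes the 4-fluorophenyl ring itself from a saturated chain carbon bound to a sulfur and puts ethoxycarbonyl there, giving an at least 1.7-fold higher number from compound 2 to compound 3 (0.23 log units; that floor lies within the scatter) and an at least 1.0-fold higher number from compound 1 to compound 3 (0.02 log units; that floor lies within the scatter). Both are floors, so the true size of each step cannot be read, and it may be small or large; what the result does show is that swapping out the ring here gives no sign of a stronger inhibitor in this assay.

The compounds shown leave open whether a carboxylic acid, an amide or a plain longer chain in place of ethoxycarbonyl would give a number rather than a limit. They also cannot separate the loss of the ring from the arrival of ethoxycarbonyl.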